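The source may report more compounds than this note shows. Statements on the series, on what has been measured and on what is new or still open speak of the compounds shown alone.

Working notes on the series.

Compound 2 `CCCCNC(=O)OCC(O)Cn1cc(CN(C)CCC(C)C)nn1` carries a carbamate on the hydroxypropyl chain at the triazole nitrogen; in an assay on nucleic acid for inhibition of Nucleic Acid, read by fluorescence, tested at 100 uM (a higher number here means more inhibition at the concentration tested (going by the name of the read-out), a lower number less inhibition), compound 2 gives 24%. That is the second highest of three numbers. Compound 1 `CCCCC(O)Cn1cc(CN(C)CC2CCCCC2)nn1` gives 47% in this assay, and compound 3 `CC(C)CCN(C)Cc1cn(CC(O)COC(=O)c2ccccc2)nn1` gives 0% in this assay. Going by the values given here, the one step measured between two compounds that differ in a single place is a number 24 percentage points lower from compound 2 to compound 3 (beyond the scatter), where the carbamate becomes a benzoate. Compound 1 and compound 2 differ in two places, so their values alone show that the chain of compound 1 with a cyclohexylmethyl amine sits above the carbamate chain of compound 2 with an isopentyl amine.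

Compound 4 `CCCCC(O)Cn1cc(CN(C)CCC(C)C)nn1` takes the chain of compound 1 while keeping the amine of compound 2: propyl in place of (butylcarbamoyl)oxy on a saturated chain carbon, two bonds along the chain from an oxygen on a saturated carbon. Among the compounds with values here, no measured step replaces the carbamate with a plain alkyl chain on this core, so the step from compound 2 to compound 3 bears only loosely, showing that the carbonyl-bearing group on this chain matters for the read-out. Compound 4 is expected to move toward compound 1 in this assay, an estimated step of a number 16 percentage points higher from compound 2 to compound 4 (beyond the scatter). Compound 4 is therefore estimated at 40% in this assay, in the range 20% to 60%.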

Compound 4, a percentage reported as inhibition, at one concentration (the size of the read-out at that concentration, not a potency): 47%
The estimate for compound 4 lay 7 percentage points below the measured number; the measured number falls inside the stated range.
By their numbers in this assay, from the lowest: compound 3; then compound 2; then compounds 1 and 4 (each within the scatter of the next).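

In this assay, the step to a plain alkyl chain is now measured directly on one amine: propyl in place of (butylcarbamoyl)oxy gives a number 23 percentage points higher from compound 2 to compound 4 (beyond the scatter), whereas the earlier step only exchanged one carbonyl-bearing group for another. At the other end of the molecule, isobutyl in place of cyclohexyl on a saturated chain carbon bound to an amine nitrogen gives no change at the digits printed from compound 1 to compound 4 (within the scatter), so these two groups cannot be told apart in this read-out. No measurement at hand offers a reason for either step.

Open, as far as these compounds go, is whether a longer chain such as hexyl in place of propyl keeps the read-out at this level, and whether a butoxy group, which has the ether oxygen but no carbonyl, reads like propyl or like the carbamate. Going by these compounds alone, also open is whether phenyl in place of isobutyl or cyclohexyl on that same saturated chain carbon bound to an amine nitrogen would leave the read-out unchanged as well, since only two saturated groups can be compared there so far.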